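This account rests on a few compounds, and the source may have more. Where it says the series, first, only, none or still open, it means among the compounds named here.

Among the compounds with values here, in a functional assay on A549 cells (Homo sapiens) for antiproliferative activity, read by MTT assay, with a stated time of 72 h (a lower number here means a stronger inhibitor, a higher number a weaker inhibitor), compound 1 `CC(C)N1C(=O)COc2ccc(-c3cccc(NS(=O)(=O)c4ccc(F)cc4)c3)cc21` gives 29400 nM, the only true number available so far. Compound 2 `O=C1COc2ccc(-c3cnc4ccccc4c3)cc2N1c1ccc(F)cc1` is reported only as a limit, > 40000 nM. Compound 3 `Cc1ccc(N2C(=O)COc3ccc(-c4cccc(NS(=O)(=O)c5ccc(F)cc5)c4)cc32)cc1` keeps the core of compound 1 and differs by 4-methylphenyl in place of isopropyl on an amide-type nitrogen in a ring, with 4-methylphenyl in place of isopropyl on an amide-type nitrogen in a ring. Within the data shown here, no measured step speaks to this change, so only a modest shift toward stronger inhibition is expected in this assay, close to the scatter. The expected step is a 2.0-fold lower number from compound 1 to compound 3 (0.29 log units; within the scatter). Compound 3 is estimated at 15000 nM, with an expected range of 5000 nM to 40000 nM.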

Compound 3, half-maximal inhibitory concentration: > 40000 nM
Compound 3: only a limit was reported; the forecaster's own chance of this, stated with the estimate: 20%; at least 2.6-fold (0.42 log units) between middle value and limit.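

In this assay, moving to the 4-methylphenyl on the amide-type nitrogen in a ring gives an at least 1.3-fold higher number from compound 1 to compound 3 (0.13 log units; that floor lies within the scatter), so this change at this position shows no sign of stronger inhibition. The value of compound 3 is a limit, and the true size of the step cannot be read from it because this floor rests on a shared limit: the limit of > 40000 nM in this assay, at which 2 of the 3 values shown sit.

Going by these compounds, whether a methyl, or a chain carrying an amine or a carboxylic acid, on this nitrogen would give a lower number than isopropyl stays open.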